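Isopropyl to tert-butyl on the aryl of compound 2

The source may hold more compounds than are shown below. What is called first, only, known or untested is meant among the compounds shown, and "the series" means these compounds.

Among the compounds with values here, compound 2 `CC(C)c1ccc(-c2nc3sccn3c2/C=N/OCc2ccc(Cl)c(Cl)c2)cc1` holds the lowest of the two numbers so far in an assay on HepG2 cells for agonist activity at nuclear receptor subfamily 1 group I member 3 (Homo sapiens), read by a luciferase reporter, with a stated time of 23 h; on this read-out lower numbers stand for an effect already at smaller amounts and higher numbers for an effect only at larger amounts of compound: compound 2 gives 590 nM, while compound 1 `CCc1nc2sccn2c1/C=N/OCc1ccc(Cl)c(Cl)c1` gives 2600 nM. Within the data shown here, the only measured step, a 4.4-fold lower number from compound 1 to compound 2 (0.64 log units; beyond the scatter), put the 4-isopropylphenyl in place of ethyl. Compound 3 `CC(C)(C)c1ccc(-c2nc3sccn3c2/C=N/OCc2ccc(Cl)c(Cl)c2)cc1` differs from compound 2 by methyl in place of hydrogen on a saturated chain carbon bound to an aromatic carbon and two saturated chain carbons. Among the measured compounds shown here, no measured step touches this saturated carbon, so the step from compound 1 to compound 2 bears on it only loosely. The expected step of a 1.3-fold lower number from compound 2 to compound 3 (0.12 log units; within the scatter) is small, within the scatter. Compound 3 is estimated at 450 nM, with a range from 150 nM to 1500 nM.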

Compound 3, half-maximal effective concentration: 2400 nM
Compound 3: middle estimate off by 5.3-fold (0.73 log units), on the low side; the measured number lies above the stated range.
By their numbers in this assay, from the lowest: compound 2; then compounds 3 and 1 (each within the scatter of the next).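

The single added methyl on this saturated chain carbon is enough to reverse the gain seen with the 4-isopropylphenyl group: isopropyl to tert-butyl gives a clear loss in this assay (a 4.1-fold higher number from compound 2 to compound 3 (0.61 log units; beyond the scatter)). With 4-(tert-butyl)phenyl in place of ethyl, the aryl group brings no separation from the ethyl compound (a 1.1-fold lower number from compound 1 to compound 3 (0.03 log units; within the scatter)), so an aryl group here does not by itself secure the lower number. No measured evidence bears on the reason for this result.

Still open, as far as these compounds go, is how a cyclopropyl, a methoxy or a carboxylic acid in place of the isopropyl would read on the same aryl. Also open, from the compounds shown here alone, is whether a plain methyl there would hold the number of compound 2.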